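This account rests on a few compounds, and the source may have more. Where it says the series, first, only, none or still open, it means among the compounds named here.

The series rests on the shared core of compound 1 `CCCCCCSC(=S)N[C@H]1CCOC1=O`, which bears a hexyl chain on its sulfur. In a functional assay on EC9706 cells (Homo sapiens) for cytotoxicity, read by MTT assay, with a stated time of 72 h (a lower number here means a stronger inhibitor, a higher number a weaker inhibitor), compound 1 gives > 128000 nM, a limit of the assay rather than a number. Compound 2 `CCCCCCCCSC(=S)N[C@H]1CCOC1=O` likewise gives > 128000 nM in this assay, again a limit. For the measured compounds named here, compound 3 `CCCCCCCCCCCCSC(=S)N[C@H]1CCOC1=O` is the one member that returns a number in this assay, 58300 nM, and so it stands as the only true value among the three. The step of an at least 2.1-fold lower number from compound 1 to compound 3 (0.34 log units; beyond the scatter) and the step of an at least 2.1-fold lower number from compound 2 to compound 3 (0.34 log units; beyond the scatter) both point the same way, while the step that the two limits leave unreadable from compound 1 to compound 2 cannot be read because of the limit of > 128000 nM in this assay, at which 2 of the 3 values shown sit. Compound 4 `CCCCCCCCCCCCCCSC(=S)N[C@H]1CCOC1=O` extends the chain once more: ethyl in place of hydrogen on a saturated chain carbon, ten or more bonds along the chain from a sulfur. If the two readable steps carry on, this assay should give a lower number for compound 4 than for compound 3, though neither of those steps shows more than a lower bound on its size. Compound 4 is therefore expected to show a modest step of a 1.5-fold lower number from compound 3 to compound 4 (0.16 log units; within the scatter), with an estimate of 40000 nM, ranging from 15000 nM to 128000 nM.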

Compound 4, half-maximal inhibitory concentration: 66200 nM
Compound 4: the middle estimate sits 1.7-fold (0.22 log units) below what was measured, within the range that was stated.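

In this assay, ethyl in place of hydrogen on a saturated chain carbon, ten or more bonds along the chain from a sulfur, gives a 1.1-fold higher number from compound 3 to compound 4 (0.06 log units; within the scatter), so the drop seen on reaching compound 3 does not carry on to compound 4. Against the shorter chains only floors can be stated, with an at least 1.9-fold lower number from compound 2 to compound 4 (0.28 log units; that floor lies within the scatter) and an at least 1.9-fold lower number from compound 1 to compound 4 (0.28 log units; that floor lies within the scatter). The hexyl change can now be compared on two cores: the same change on two cores in this assay, an at least 2.1-fold lower number (0.34 log units; beyond the scatter) from compound 1 to compound 3 and an at least 1.9-fold lower number (0.28 log units; that floor lies within the scatter) from compound 2 to compound 4; the limit leaves it open whether they differ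

On these data alone, whether a longer chain on the sulfur, or an amine in place of the chain, would give a number apart from those of compound 3 and compound 4 stays open. How far compound 1 and compound 2 truly lie from the two longer chains also stays open: the limit of > 128000 nM in this assay, at which 2 of the 4 values shown sit.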